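The source may hold more compounds than are shown below. What is called first, only, known or untested is meant among the compounds shown, and "the series" means these compounds.

Measured compounds:
compound 1, `CC(CN)NC(=O)c1cc(C2CC2)nc2c1cnn2C(C)C`, 164000 nM
compound 2, `CCn1ncc2c(C(=O)NCCN(C)C)cc(C3CC3)nc21`, > 300000 nM

Both compounds were tested in an ADME assay on Vero cells (Chlorocebus sabaeus) for cytotoxicity, read by neutral red uptake, with a stated time of 3 days; a lower number here means that less compound is tolerated, a higher number that more compound is tolerated. Compound 1 gives 164000 nM in this assay. Compound 2 reaches only a limit of the assay, > 300000 nM, so its true value is not a number. Within the data shown here, this is the limit of > 300000 nM in this assay, at which 1 of the 2 values shown sits, and it places compound 2 at the edge of what this assay can report, with compound 1 as the only fixed number for comparison.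

The next compound, compound 3, `CC(C1CC1)n1ncc2c(C(=O)NCCN(C)C)cc(C3CC3)nc21`, is not yet measured. It differs from compound 2 in one place: cyclopropyl in place of hydrogen on a saturated chain carbon bound to an aromatic nitrogen and a saturated chain carbon. Among the measured compounds shown here, no step between two measured compounds is known for this change, so any expectation rests on the two values shown. Compound 1 shows that a compound of this core can give a number below the limit, and compound 2 shows that the limit is reachable. For compound 3 a modest move toward less tolerance is expected, an at least 1.5-fold lower number from compound 2 to compound 3 (0.17 log units; that floor lies within the scatter), of a size that may still fall within the usual scatter. Compound 3 is therefore estimated at 200000 nM in this assay, expected to lie between 80000 nM and 320000 nM.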

Compound 3, half-maximal cytotoxic concentration: 51700 nM
Beside the measured number, compound 3's estimate is 3.9-fold (0.59 log units) above it, and the stated range ends above it.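

In this assay, the result gives the first measured effect of a change at this position: cyclopropyl in place of hydrogen on a saturated chain carbon bound to an aromatic nitrogen and a saturated chain carbon gives an at least 5.8-fold lower number from compound 2 to compound 3 (0.76 log units; beyond the scatter). Read as ethyl to 1-cyclopropylethyl, this change brings the series from a limit of the assay to a fixed number, so that less of compound 3 is tolerated and the position clearly matters for this read-out. The printed step is only a floor, because the starting point for compound 2 is a limit and not a number: the limit of > 300000 nM in this assay, at which 1 of the 3 values shown sits.

The compounds shown leave open whether the three-membered ring itself matters or whether any added carbon on this chain would do the same, a question that an open chain such as propyl, or a larger ring such as cyclobutyl, at the same place could help to answer. They also leave open how large the true step is, and whether the same change would act in the same way with a different amide side chain.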